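This account rests on a few compounds, and the source may have more. Where it says the series, first, only, none or still open, it means among the compounds named here.

Compound 2 `CC(C)C1=C(N2CC2)C(=O)C=C(N2CC2)C1=O` is one of two compounds tested in a functional assay on L1210 cells (Mus musculus), with a stated time of 1 days; on this read-out higher numbers stand for higher potency (the scale is a negative logarithm) and lower numbers for lower potency. In this assay compound 2 gives 4.59, the lowest of the two numbers, while compound 1 `CC1=C(N2CC2)C(=O)C(C(C)C)=C(N2CC2)C1=O` gives 4.69; the step of a number 0.10 log units lower from compound 1 to compound 2 (within the scatter) is within the scatter. Compound 3 `CC(C)C1=C(N2CC2)C(=O)C(C(C)C)=C(N2CC2)C1=O` has not yet been measured. The change from compound 2 to compound 3 is isopropyl in place of hydrogen on a double-bonded ring carbon. Among the measured compounds shown here, the one measured step, a number 0.10 log units lower from compound 1 to compound 2 (within the scatter), runs the opposite way and is small, so no step beyond the scatter is expected, and compound 3 is estimated at 4.75, between 4.4 and 5.1, an expected step of a number 0.16 log units higher from compound 2 to compound 3 (within the scatter).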

Compound 3, logarithm of the reciprocal of the active concentration, log(1/C): 4.14
Compound 3: middle estimate off by 0.61 log units, on the high side, and the stated range ends above it.
By their numbers in this assay, from the lowest: compound 3; then compounds 2 and 1 (each within the scatter of the next).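

At this double-bonded ring carbon, hydrogen and methyl could not be told apart in this assay, but isopropyl does stand apart, giving a number 0.45 log units lower from compound 2 to compound 3 (beyond the scatter) and a number 0.55 log units lower from compound 1 to compound 3 (beyond the scatter). Among the compounds shown here, the position is therefore not indifferent to the group it carries, although only three groups are compared here. Nothing available explains the loss. Still open, on these data alone, is whether ethyl already lowers the number or whether a longer chain such as butyl lowers it further. As far as these compounds go, how an amine or a methoxy group would read at this carbon also remains unknown.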